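Swapping a Methylbenzyl Arm for a Chlorobenzyl One

This account rests on a few compounds, and the source may have more. Where it says the series, first, only, none or still open, it means among the compounds named here.

Compound 1 `Cc1cccc(Cn2cc(CCCCC[C@@H]3SC[C@@H]4NC(=O)N[C@@H]43)nn2)c1` carries the shared core with a 3-methylbenzyl group on its triazole. In an assay on isolated protein for inhibition of biotin--protein ligase (Homo sapiens), read by scintillation counting, with a stated time of 10 min (a higher number here means a weaker inhibitor, a lower number a stronger inhibitor), compound 1 gives only a limit, > 16000 nM. Compound 2 `O=C1N[C@H]2[C@H](CS[C@H]2CCCCCc2cn(Cc3ccc(C(F)(F)F)cc3)nn2)N1` likewise gives only a limit, > 16000 nM. Compound 3 `O=C1N[C@H]2[C@H](CS[C@H]2CCCCCc2cn(Cc3ccccc3F)nn2)N1` also gives only a limit, > 16000 nM. Because all three sit at the limit of > 16000 nM in this assay, at which 3 of the 3 values shown sit, the steps a step that the two limits leave unreadable from compound 1 to compound 2, a step that the two limits leave unreadable from compound 1 to compound 3 and a step that the two limits leave unreadable from compound 2 to compound 3 cannot be read in size or direction. Compound 4 `O=C1N[C@H]2[C@H](CS[C@H]2CCCCCc2cn(Cc3ccccc3Cl)nn2)N1` differs from compound 1 by 2-chlorophenyl in place of 3-methylphenyl on a saturated chain carbon bound to an aromatic nitrogen. Going by the values given here, no measured step shows that a change on this benzyl group moves the result off the limit, so compound 4 is expected to stay there, with an expected step that the limit leaves unreadable from compound 1 to compound 4. The estimate for compound 4 is 30000 nM, with a range from 8000 nM to 120000 nM.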

Compound 4, inhibition constant: > 16000 nM
Compound 4: no number, only a limit (the forecaster's own chance of this, stated with the estimate: 85%); the middle value is on the limit's open side.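

In this assay compound 4 gives only a limit, > 16000 nM. The steps to it from compound 1, compound 2 and compound 3 cannot be read, because all four share one limit: the limit of > 16000 nM in this assay, at which 4 of the 4 values shown sit.

From the compounds shown here alone, how far these four compounds lie past that limit, and whether any benzyl group on the shared core would give a measurable inhibition constant, stays open.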